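The source may hold more compounds than are shown below. What is called first, only, known or untested is meant among the compounds shown, and "the series" means these compounds.

Measured so far in an in vitro assay on HEK-tsA201 cells for antagonist activity at Neuronal acetylcholine receptor; alpha3/beta4 (Homo sapiens), read by fluorescence and calcium flux; a higher number here means a weaker inhibitor, a lower number a stronger inhibitor:
Compound 1 `C=CCOc1ccc(C(=O)Nc2cccc(C)n2)cc1` gives 31700 nM.
Compound 2 `C=CCOc1ccc(C(=O)Nc2cccc(Cl)n2)cc1` gives only a limit of the assay, > 100000 nM.
Compound 3 `C=CCOc1ccc(C(=O)Nc2cccc(CC)n2)cc1` gives 27400 nM.

The three compounds share a core and differ only in the group on one aromatic carbon. There, the step of an at least 3.1-fold higher number from compound 1 to compound 2 (0.49 log units; beyond the scatter) and the step of an at least 3.6-fold lower number from compound 2 to compound 3 (0.56 log units; beyond the scatter) are both beyond the scatter, while the step of a 1.2-fold lower number from compound 1 to compound 3 (0.06 log units; within the scatter) is within it. Compound 3 and compound 1 therefore sit within the scatter of each other, and compound 2 gives only a limit.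

Compound 4 `CCCOc1ccc(C(=O)Nc2cccc(CC)n2)cc1` keeps the group on the aromatic carbon of compound 3 and changes the other end of the molecule: ethyl in place of vinyl on a saturated chain carbon bound to an oxygen on an aromatic ring. Among the compounds with values here, none of the measured steps touches this place; all of them change the group on the aromatic carbon, so none bears directly on this change. Within the data shown here, with no measured step on the allyloxy side, the expected step of a 1.0-fold lower number from compound 3 to compound 4 (0.01 log units; within the scatter) from compound 3 to compound 4 is none beyond the scatter. For compound 4 the estimate in this assay is 27000 nM, with a range from 12000 nM to 65000 nM.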

Compound 4, half-maximal inhibitory concentration: 29200 nM
For compound 4 the middle estimate is 1.1-fold (0.03 log units) below the measured one, within the range that was stated.
By their numbers in this assay, from the lowest: compounds 3, 4 and 1 (each within the scatter of the next). At a limit, above all of these: compound 2.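

In this assay, within the data shown here, the only change on the allyloxy side of the molecule gives a 1.1-fold higher number from compound 3 to compound 4 (0.03 log units; within the scatter), so allyloxy and propoxy cannot be told apart at this place. The earlier compounds shown here varied only the group on the aromatic carbon at the other end, and this step adds that, with ethyl held there, the double bond outside the aromatic rings can be replaced by a saturated chain and the two values stay within the scatter of each other. Nothing measured here explains this result.

It remains open whether a longer chain, a branched chain, a benzyl group or a terminal hydroxyl on this oxygen would give a step beyond the scatter, as the compounds shown carry only allyloxy and propoxy there. Also open, from the compounds shown here alone, is whether propoxy behaves like allyloxy when methyl or chloro sits on the aromatic carbon, as propoxy appears here only with ethyl.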